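This account rests on a few compounds, and the source may have more. Where it says the series, first, only, none or still open, it means among the compounds named here.

Measured so far:
Compound 2 `Cc1cccc(C)c1S(=O)(=O)NC[C@@H](O)CN1CCC[C@@]2(CCN(c3ncnc(N)c3C3CC3)C2)C1` gives 4 nM in an assay on isolated protein for inhibition of RAC-alpha serine/threonine-protein kinase (Homo sapiens); a higher number here means a weaker inhibitor, a lower number a stronger inhibitor.
Compound 1 `CCOCCN(C[C@@H](O)CN1CCCC2(CCN(c3ncncc3C3CC3)C2)C1)S(=O)(=O)c1c(C)cccc1C` gives 12 nM in this assay.

Compound 2 has the lower of these two numbers, and compound 1 is beyond the scatter from it. Compound 3 `Nc1ncnc(N2CC[C@@]3(CCCN(C[C@H](O)CNS(=O)(=O)c4ccccc4Br)C3)C2)c1C1CC1` is related to compound 2 by one change, (2-bromophenyl in place of 2,6-dimethylphenyl on a sulfonyl sulfur). Going by the values given here, no measured pair shows this change, so the expectation rests on the two values shown and on the change itself. The step from compound 2 to compound 3 in this assay is expected to be small, about a 1.5-fold higher number from compound 2 to compound 3 (0.18 log units; within the scatter), with no clear direction beyond the scatter. For compound 3 the estimate in this assay is 6 nM, within 2 nM to 20 nM.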

Compound 3, half-maximal inhibitory concentration: 17 nM
The estimate for compound 3 lay 2.8-fold (0.45 log units) below the measured number, within the range that was stated.
By their numbers in this assay, from the lowest: compound 2; then compounds 1 and 3 (each within the scatter of the next).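

In this assay the exchange of 2,6-dimethylphenyl for 2-bromophenyl on the sulfonyl sulfur gives a 4.3-fold higher number from compound 2 to compound 3 (0.63 log units; beyond the scatter), a modest step. This position therefore responds to the aryl group it carries, and of this pair the 2,6-dimethylphenyl group gives the lower number. No measurement shown here explains the step.

On these data alone, whether the step follows the bromine or the missing methyl stays open. A 2-methylphenyl or 2-chlorophenyl group on the sulfonyl sulfur would separate the two.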